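The compounds below may be only part of what the source reports. "The series", "measured", "known", "first", "only" and "open" are said of these compounds alone.

Compound 1 `Cc1nc(N(C)c2ccc(OCCCCC(=O)NO)cc2)c2ccccc2n1`, compound 2 `Cc1nc(N(C)c2cccc(OCC(=O)NO)c2)c2ccccc2n1` and compound 3 `Cc1nc(N(C)c2cccc(OCCCC(=O)NO)c2)c2ccccc2n1` share one core and were each tested in an assay on isolated protein for inhibition of histone deacetylase 8 (Homo sapiens), read by fluorescence, with a stated time of 1 h; a lower number here means a stronger inhibitor, a higher number a weaker inhibitor. Compound 1 gives 1700 nM. For compound 2 the assay reports only a limit, > 1000 nM. For compound 3 the assay likewise reports only a limit, > 1000 nM. Going by the values given here, the single step between neighbours, a step that the two limits leave unreadable from compound 2 to compound 3, cannot be sized because of the limit of > 1000 nM in this assay, at which 2 of the 3 values shown sit. Compound 2 therefore stands at the limit with no number of its own, and of the three values shown only compound 1 carries a number.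

Compound 4 `COc1ccc(N(C)c2nc(C)nc3ccccc23)cc1OCC(=O)NO` differs from compound 2 in one place: methoxy in place of hydrogen on an aromatic carbon. Among the compounds with values here, no measured step touches this change, and the one step in the set, a step that the two limits leave unreadable from compound 2 to compound 3, concerns the chain and is itself unreadable. With compound 2 at the limit, the expectation for compound 4 rests on that limit alone: the step that the limit leaves unreadable from compound 2 to compound 4 is expected to be no more than the scatter, and a limit is again the most likely report. Compound 4 is accordingly estimated at 3000 nM, within a range from 1000 nM to 10000 nM.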

Compound 4, half-maximal inhibitory concentration: > 1000 nM
Compound 4: no number, only a limit (the forecaster's own chance of this, stated with the estimate: 70%); the middle value does not contradict the limit.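

No step can be read from compound 2 to compound 4, because each of the two carries only a limit and no number: the limit of > 1000 nM in this assay, at which 3 of the 4 values shown sit. The compounds shown leave open whether methoxy in place of hydrogen on an aromatic carbon alters inhibition at all, and what actual values compound 2, compound 3 and compound 4 would have.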